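Removing the Chain Carbon Before a Fluorophenyl Group

The source may hold more compounds than are shown below. What is called first, only, known or untested is meant among the compounds shown, and "the series" means these compounds.

Three measured compounds share one core and differ only in the group attached to a saturated chain carbon bound to an aromatic carbon. Compound 1 `COc1ccc(F)cc1CNCCCNc1ccnc2cc(CCc3ccccc3)ccc12` carries a benzyl group there, compound 2 `COc1ccc(F)cc1CNCCCNc1ccnc2cc(CC(C)C)ccc12` an isopropyl group, and compound 3 `COc1ccc(F)cc1CNCCCNc1ccnc2cc(Cc3ccc(F)cc3)ccc12` a 4-fluorophenyl group. In an ADME assay for permeability, using PAMPA, with a stated time of 30 min, at pH 7.4 (on this read-out lower numbers stand for lower permeability and higher numbers for higher permeability), compound 1 gives 23 10^-6 cm/s, compound 2 gives 23 10^-6 cm/s, and compound 3 gives 23 10^-6 cm/s. Compound 3 thus stands level with both of its companions: the steps of no change at the digits printed from compound 1 to compound 3 (within the scatter) and no change at the digits printed from compound 2 to compound 3 (within the scatter), like the step of no change at the digits printed from compound 1 to compound 2 (within the scatter), all lie within the usual scatter of this measurement.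

Compound 4 `COc1ccc(F)cc1CNCCCNc1ccnc2cc(-c3ccc(F)cc3)ccc12` takes a different kind of step: 4-fluorophenyl in place of 4-fluorobenzyl on an aromatic carbon. The aromatic ring now sits directly on the aromatic carbon of the fused two-ring system, without the saturated chain carbon that carried it in compound 3. None of the three measured steps removes a chain carbon in this way; each only exchanged the group on that carbon, and each left this assay unchanged. With no movement seen in any of them, the step of no change at the digits printed from compound 3 to compound 4 (within the scatter) is expected to stay within the scatter as well. Compound 4 is therefore estimated at 23 10^-6 cm/s, with a range from 12 10^-6 cm/s to 40 10^-6 cm/s.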

Compound 4, apparent permeability: 237 10^-6 cm/s
Compound 4: middle estimate off by 10-fold (1.01 log units), on the low side; the measured number lies above the stated range.
By their numbers in this assay, from the lowest: compounds 1, 2 and 3 (each within the scatter of the next); then compound 4.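

In this assay this position turns out not to be indifferent: exchanging the group on the chain carbon left the number level, yet putting the 4-fluorophenyl directly on the aromatic carbon gives a 10-fold higher number from compound 3 to compound 4 (1.01 log units; beyond the scatter) and, against the other two compounds, a 10-fold higher number from compound 2 to compound 4 (1.01 log units; beyond the scatter) and a 10-fold higher number from compound 1 to compound 4 (1.01 log units; beyond the scatter) as well. The group that leaves and the group that enters each hold one six-membered aromatic ring of carbon only and carry no net charge, so a small change in atoms goes with a large step, and among these four compounds the three with a saturated chain carbon at this position sit level while the one without it stands apart. Nothing among the data shown explains why the number moves so far.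

The compounds shown leave open whether the high number goes with any group bound directly to this aromatic carbon or only with the 4-fluorophenyl. A plain phenyl ring without the fluorine, a small amine or a carboxylic acid at the same place would help separate these two readings.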